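Ring-nitrogen substituents on a hydroxyphenyl pyrrolidine series

A few compounds are considered here, and "the series" means these few. Any claim that something is new, unique, unknown or untested is made for them only; others in the source may bear on it.

Measured so far:
compound 1, `CC(C)C(=O)N1C[C@@H](C/C=C\CCC(=O)O)[C@@H](c2ccccc2O)C1`, 0.11 mg/kg
compound 2, `O=C(O)CCC/C=C\C[C@@H]1CN(S(=O)(=O)c2cccc3ccccc23)C[C@@H]1c1ccccc1O`, 0.08 mg/kg
compound 3, `O=C(O)CC/C=C\C[C@@H]1CN(S(=O)(=O)c2ccc(Cl)cc2)C[C@H]1c1ccccc1O`, 0.12 mg/kg

All three compounds were tested in a functional assay on the whole organism (trachea) for inhibition, with Cavia porcellus as the target; on this read-out higher numbers stand for an effect only at larger amounts of compound and lower numbers for an effect already at smaller amounts. Compound 1 gives 0.11 mg/kg, the second highest of the three numbers. Its nearest neighbour is compound 3, whose value of 0.12 mg/kg lies within the scatter of compound 1; its furthest is compound 2 with 0.08 mg/kg, also within the scatter. The three numbers therefore cannot be ordered against each other on this evidence.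

Compound 4, `O=C(O)CC/C=C\C[C@@H]1CN(S(=O)(=O)c2ccc(Cl)cc2)C[C@@H]1c1ccccc1O`, has not yet been measured in this assay. It differs from compound 1 in one place: (4-chlorophenyl)sulfonyl in place of isopropylcarbonyl on an amine nitrogen in a ring. Compound 3 carries the same (4-chlorophenyl)sulfonyl group on its ring nitrogen and gives 0.12 mg/kg, and compound 2, with another sulfonyl group on that nitrogen, gives 0.08 mg/kg; both numbers sit close to compound 1. No step beyond the scatter is therefore expected from compound 1 to compound 4, and the estimated step of a 1.2-fold lower number from compound 1 to compound 4 (0.09 log units; within the scatter) is small. For compound 4 a value of 0.09 mg/kg is expected, within a range from 0.04 mg/kg to 0.2 mg/kg.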

Compound 4, dose for 50% inhibition: 0.03 mg/kg
Beside the measured number, compound 4's estimate is 3.0-fold (0.48 log units) above it, and the stated range ends above it.
By their numbers in this assay, from the lowest: compound 4; then compounds 2, 1 and 3 (each within the scatter of the next).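

In this assay, going by these compounds alone, the ring nitrogen now shows a step beyond the scatter, which the earlier compounds could not show: a 3.7-fold lower number from compound 1 to compound 4 (0.56 log units; beyond the scatter) with (4-chlorophenyl)sulfonyl in place of isopropylcarbonyl. This group on the ring nitrogen does not settle the number by itself, as a 4.0-fold lower number from compound 3 to compound 4 (0.60 log units; beyond the scatter) with the atoms and bonds unchanged and one stereocentre at a saturated ring carbon drawn R in compound 3 and S in compound 4. The step of similar size within this pair can be assigned to configuration alone, because nothing else separates the two structures: the fact that compounds 3 and 4 differ only in the configuration as drawn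

The step from isopropylcarbonyl to (4-chlorophenyl)sulfonyl changes the carbonyl link, the aromatic ring and the chlorine together, so these parts cannot be told apart here; methylsulfonyl or benzoyl on the same nitrogen would begin to separate them. Also open, going by these compounds, is whether the same configuration at that ring carbon gives a lower number with isopropylcarbonyl on the nitrogen, which a compound pair carrying that group in both configurations would show.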